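Exchanging one fluorinated group on compound 2

The source may hold more compounds than are shown below. What is called first, only, known or untested is meant among the compounds shown, and "the series" means these compounds.

Compound 1 `CC(O)(CSc1cccc(C(F)(F)F)c1)C(=O)Nc1cccc(S(F)(F)(F)(F)F)c1`: 12900 nM
Compound 2 `CC(O)(CSc1cc(C(F)(F)F)cc(C(F)(F)F)c1)C(=O)Nc1cccc(S(F)(F)(F)(F)F)c1`: 4400 nM
Compound 3 `CC(O)(CSc1cc(C(F)(F)F)cc(C(F)(F)F)c1)C(=O)Nc1cccc(C(F)(F)C(F)(F)F)c1`: not yet measured

In a functional assay on CWR22R cells (Homo sapiens) for antiproliferative activity, read by propidium iodide staining, with a stated time of 96 h (on this read-out higher numbers stand for weaker inhibition and lower numbers for stronger inhibition), compound 2 stands at 4400 nM as the lower of the two numbers. Going to compound 3 brings a group of 7 heavy atoms (2 carbon, 5 fluorine; no ring) in place of a group of 6 heavy atoms (5 fluorine, 1 sulfur; no ring), on an aromatic carbon and the entering 1,1,2,2,2-pentafluoroethyl sits meta to a large group. Within the data shown here, the only measured step, a 2.9-fold lower number from compound 1 to compound 2 (0.47 log units; beyond the scatter) and modest, was trifluoromethyl in place of hydrogen on an aromatic carbon, a different change that bears only loosely here. No shift beyond the scatter is therefore expected, and the estimated step is a 1.1-fold higher number from compound 2 to compound 3 (0.06 log units; within the scatter) in this assay for this exchange. Compound 3 is expected at 5000 nM with an estimated range from 2000 nM to 12000 nM on this read-out.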

Compound 3, half-maximal inhibitory concentration: 4200 nM
Beside the measured number, compound 3's estimate is 1.2-fold (0.08 log units) above it, and the stated range covers the measured number.
By their numbers in this assay, from the lowest: compounds 3 and 2 (each within the scatter of the next); then compound 1.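

In this assay the exchange at this position, on an aromatic carbon and meta to a large group, gives a 1.0-fold lower number from compound 2 to compound 3 (0.02 log units; within the scatter) and so 1,1,2,2,2-pentafluoroethyl and the sulfur-bearing group of 6 heavy atoms cannot be told apart on this read-out. Among these compounds, the earlier step lay in a different place, so this is the first reading for this position. Nothing available explains why the two groups read alike.

From the compounds shown here alone, whether a nitrile, an amine or a carboxylic acid here would move the number beyond the scatter remains open. So does whether the same exchange would read alike with a single trifluoromethyl, as in compound 1, on the other side of the molecule.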